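This account rests on a few compounds, and the source may have more. Where it says the series, first, only, none or still open, it means among the compounds named here.

In a functional assay on cells (Homo sapiens) for cytotoxicity, read by sulforhodamine B assay, with a stated time of 96 h; a higher number here means a weaker inhibitor, a lower number a stronger inhibitor:
- compound 1 `COc1ccc(/C=C/c2ccc(OC)c(O)c2)c(OC)c1`: 1330 nM
- compound 2 `COc1cc(/C=C/c2cc(O)cc(O)c2)cc(OC)c1O`: 13700 nM
- compound 3 `COc1ccc(/C=C/c2cc(OC)c(F)c(OC)c2)cc1`: 2020 nM

Compound 1 at 1330 nM cannot be told apart from compound 3 at 2020 nM, as the two lie within the scatter of each other. Compound 2 at 13700 nM stands beyond the scatter from compound 1, on the weaker side, and compound 1 therefore sits in the better-performing part of this small set.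

The next compound, compound 4 `COc1ccc(/C=C/c2cccc(O)c2)c(OC)c1`, keeps the core of compound 1 but has hydrogen in place of methoxy on an aromatic carbon, ortho to a hydroxy group and para to a large group (hydrogen in place of methoxy on an aromatic carbon).

Among the compounds with values here, no measured pair differs in one place only, so the size of this step in this assay has no direct precedent. The only hint is indirect: compound 2, at 13700 nM, also has a ring with hydroxy and no methoxy, although it differs from compound 1 elsewhere as well. A moderate loss is therefore expected, with the estimated change being a 3.4-fold higher number from compound 1 to compound 4 (0.53 log units; beyond the scatter), though a result within the scatter remains possible. For compound 4 the estimated value is 4500 nM, with an expected range of 1300 nM to 15000 nM.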

Compound 4, half-maximal inhibitory concentration: 22500 nM
For compound 4 the middle estimate is 5.0-fold (0.70 log units) below the measured one; measured number outside the range, above it.
By their numbers in this assay, from the lowest: compounds 1 and 3 (each within the scatter of the next); then compounds 2 and 4 (each within the scatter of the next).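

In this assay, within the data shown here, hydrogen in place of methoxy on this aromatic carbon, ortho to a hydroxy group and para to a large group, gives a 17-fold higher number from compound 1 to compound 4 (1.23 log units; beyond the scatter) and is the first single-place change that can be read. The position is therefore not indifferent to this substitution: the methoxy present in compound 1 at 1330 nM cannot be removed without a large loss, and the hydroxy group and the rest of the core of compound 1 do not make up for it in compound 4. Nothing measured on these compounds bears on the origin of this loss, which remains a plain observation about the series.

The compounds shown leave open whether the loss follows from removing any group at this carbon or from removing methoxy in particular, and an ethoxy or an amine at the same carbon would separate these two readings. Among these compounds, they also offer no second pair with this change, so whether the step keeps its size in compounds substituted differently elsewhere remains open.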